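Methoxyphenyl triazole esters of a triterpenoid acid: positional isomer

This account rests on a few compounds, and the source may have more. Where it says the series, first, only, none or still open, it means among the compounds named here.

Compound 1 `COc1cccc(-n2cc(COC(=O)/C(C)=C/CC/C(C)=C/CC/C(C)=C/CC[C@@H]3[C@@]4(C)CCC(=O)C(C)(C)[C@H]4CC[C@@]3(C)O)nn2)c1` carries a 3-methoxyphenyl on the triazole of the shared core. In a functional assay on DU-145 cells (Homo sapiens) for antiproliferative activity, read by MTT assay, with a stated time of 48 h (on this read-out lower numbers stand for stronger inhibition and higher numbers for weaker inhibition), compound 1 gives only a limit, > 150000 nM. Compound 2 `C/C(=C\CC/C(C)=C/CC[C@@H]1[C@@]2(C)CCC(=O)C(C)(C)[C@H]2CC[C@@]1(C)O)CC/C=C(\C)C(=O)OCc1cn([C@@H]2C[C@@H](n3cc(C)c(=O)[nH]c3=O)O[C@H]2CO)nn1`, which bears a thymidine-derived substituent at the same position of the shared core, gives a measured number in this assay, 13800 nM. For the measured compounds named here, no step between measured compounds that differ in one place is available in this set; the two values only show that compound 2 yields a number where compound 1 does not.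

Compound 3 `COc1ccccc1-n1cc(COC(=O)/C(C)=C/CC/C(C)=C/CC/C(C)=C/CC[C@@H]2[C@@]3(C)CCC(=O)C(C)(C)[C@H]3CC[C@@]2(C)O)nn1` is the unmeasured isomer. The change from compound 1 is 2-methoxyphenyl in place of 3-methoxyphenyl on an aromatic nitrogen. The atoms are the same and only the attachment point on the aromatic ring moves. Because compound 1 sits at the limit of > 150000 nM in this assay, at which 1 of the 2 values shown sits, the most likely outcome for compound 3 is again a limit rather than a number. The step of a number no higher from compound 1 to compound 3 (the limit leaves the size open) is expected to be none beyond the scatter. Compound 3 is therefore estimated at 150000 nM, with a range from 30000 nM to 600000 nM.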

Compound 3, half-maximal inhibitory concentration: > 150000 nM
Compound 3 was reported as a limit (the forecaster's own chance of this, stated with the estimate: 70%); the middle value sits exactly at the limit.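

Compound 1 and compound 3 are both reported only as limits in this assay, so no step can be read between them: the limit of > 150000 nM in this assay, at which 2 of the 3 values shown sit.

The compounds shown leave open whether 2-methoxyphenyl and 3-methoxyphenyl on the triazole differ at all in antiproliferative activity, since neither isomer gives a number.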